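The source may report more compounds than this note shows. Statements on the series, on what has been measured and on what is new or still open speak of the compounds shown alone.

Four compounds share one core. Compound 1 `COc1cc(OC)c2c(=O)cc(C(=O)Nc3ccc(N4CCN(C)CC4)cc3)[nH]c2c1` is measured in a functional assay on KOPN-8 cells (Homo sapiens) for antiproliferative activity, with a stated time of 72 h (on this read-out higher numbers stand for an effect only at larger amounts of compound and lower numbers for an effect already at smaller amounts), and gives only a limit there, > 19800 nM. Compound 2 `COc1cc(OC)c2c(=O)cc(C(=O)Nc3cccc(N4CCCC4)c3)[nH]c2c1` gives in this assay only a limit, > 58600 nM. Going by the values given here, compound 3 `COc1cc(OC)c2c(=O)cc(C(=O)Nc3cccc(-c4nccs4)c3)[nH]c2c1` likewise gives in this assay only a limit, > 54000 nM, so compound 3 stands at a limit like every value so far. The step that the two limits leave unreadable from compound 2 to compound 3 cannot be sized because both its ends are limits the limit of > 58600 nM in this assay, at which 1 of the 3 values shown sits (the limit of > 54000 nM in this assay, at which 1 of the 3 values shown sits). Compound 4 `COc1cc(OC)c2c(=O)cc(C(=O)Nc3cccc(-n4ccnc4)c3)[nH]c2c1` differs from compound 3 by 1H-imidazol-1-yl in place of 1,3-thiazol-2-yl on an aromatic carbon. Among the compounds with values here, no measured step reads on this change, and the remaining value, (the limit of > 19800 nM in this assay, at which 1 of the 3 values shown sits), is also a limit. The step of an at least 1.0-fold lower number from compound 3 to compound 4 (0.03 log units; that floor lies within the scatter) is therefore expected to stay within the scatter, most likely again as a limit. The estimate for compound 4 in this assay is 50000 nM, between 10000 nM and 200000 nM.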

Compound 4, half-maximal effective concentration: > 16300 nM
Compound 4 was reported as a limit; the forecaster's own chance of this, stated with the estimate: 85%; the middle value is on the limit's open side.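

Compound 4, like compound 2 and compound 3, gives only a limit in this assay, so the steps linking these compounds cannot be read. The compounds shown leave open what amount of any of them would produce a half-maximal effect.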